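This account rests on a few compounds, and the source may have more. Where it says the series, first, only, none or still open, it means among the compounds named here.

In an ADME assay on the whole organism (plasma) for pharmacokinetics, with Rattus norvegicus as the target, with a stated time of 24 h, at a dose of 10 mg/kg by the oral route (on this read-out higher numbers stand for higher exposure at the dose given and lower numbers for lower exposure), compound 1 (`Cc1ccc2c(c1)c(-c1ccc[nH]c1=O)c(C(=O)NS(C)(=O)=O)n2Cc1cc(F)ccc1F`) gives 10400 ng.h/mL and compound 2 (`Cc1ccc2c(c1)c(-c1ccc[nH]c1=O)c(C(=O)NS(=O)(=O)C(C)C)n2Cc1cc(F)ccc1F`) gives 3400 ng.h/mL while compound 3 (`CCc1ccc2c(c1)c(-c1ccc[nH]c1=O)c(C(=O)NS(C)(=O)=O)n2Cc1cc(F)ccc1F`) gives 35000 ng.h/mL as the highest of the three numbers. Compound 4 (`CCc1ccc2c(c1)c(-c1ccc[nH]c1=O)c(C(=O)NS(=O)(=O)C1CC1)n2Cc1cc(F)ccc1F`) differs from compound 3 by one change, cyclopropyl in place of methyl on a sulfonyl sulfur. The closest measured precedent is isopropyl in place of methyl on a sulfonyl sulfur (a 3.1-fold lower number from compound 1 to compound 2 (0.49 log units; beyond the scatter)), a modest step beyond the scatter. The other measured step (a 3.4-fold higher number from compound 1 to compound 3 (0.53 log units; beyond the scatter)) does not touch the sulfonyl sulfur. Going by the values given here, no cyclopropyl compound has been measured, so a modest drop of similar or smaller size is expected in this assay with real uncertainty. The estimate means a step (a 2.5-fold lower number from compound 3 to compound 4 (0.40 log units; beyond the scatter)) that remains an expectation. Compound 4 is expected at 14000 ng.h/mL (estimated range 5000 ng.h/mL to 35000 ng.h/mL).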

Compound 4, area under the concentration-time curve: 6140 ng.h/mL
For compound 4 the middle estimate is 2.3-fold (0.36 log units) above the measured one; the range from low to high includes it.
By their numbers in this assay, from the lowest: compounds 2, 4 and 1 (each within the scatter of the next, the first and the last beyond it); then compound 3.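

In this assay, cyclopropyl in place of methyl on the sulfonyl sulfur gives a 5.7-fold lower number from compound 3 to compound 4 (0.76 log units; beyond the scatter). The loss seen earlier with isopropyl at this sulfur therefore also appears with a ring, and in a compound carrying ethyl rather than methyl on the core. The data shown offer no explanation for this loss. As far as these compounds go, it remains open how a phenyl group or a dimethylamino group on this sulfur would behave. Whether any group here can match the methyl of compound 3 also stays unanswered.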